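Aminophenyl to Difluorophenyl: One Change, One Expectation

The compounds below may be only part of what the source reports. "The series", "measured", "known", "first", "only" and "open" are said of these compounds alone.

Compound 1 `COc1cc(-c2cc(/C=C/C(=O)c3ccc(N)cc3)[nH]n2)cc(OC)c1OC`: 98%
Compound 2 `COc1ccc(-c2cc(/C=C/C(=O)c3cc(OC)c(OC)c(OC)c3)[nH]n2)cc1OC`: 99%

In a functional assay on U-251 cells (Homo sapiens) for cytotoxicity, read by sulforhodamine B assay, with a stated time of 48 h, tested at 0.01 uM (a lower number here means a stronger effect, a higher number a weaker effect of the compound at the concentration tested), compound 1 gives 98%, the lowest of the two numbers; compound 2 gives 99%, which lies within the scatter of it, so the two cannot be ordered. Compound 3 `COc1cc(-c2cc(/C=C/C(=O)c3ccc(F)c(F)c3)[nH]n2)cc(OC)c1OC` has not yet been measured. It differs from compound 1 in one place: 3,4-difluorophenyl in place of 4-aminophenyl on a carbonyl carbon. For the measured compounds named here, no pair of measured compounds that differ in one place is available, so the step cannot be read off. Both measured compounds give numbers near the top of the scale, which leaves little room for a weaker effect, and nothing shown points to a stronger one. Compound 3 is expected at 96% (range 84% to 105%), meaning a step of a number 2 percentage points lower from compound 1 to compound 3 (within the scatter) expected to stay within the scatter.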

Compound 3, a percentage reported as activity, at one concentration (the size of the read-out at that concentration, not a potency): 97%
Estimate against measurement, compound 3: 1 percentage points below, within the range that was stated.
By their numbers in this assay, from the lowest: compounds 3, 1 and 2 (each within the scatter of the next).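

In this assay the swap on the carbonyl carbon gives a number 1 percentage points lower from compound 1 to compound 3 (within the scatter) and so shows that 3,4-difluorophenyl and 4-aminophenyl cannot be told apart at this position. The 4-aminophenyl group's hydrogen-bond donor and acceptor leave with the change, yet the number stays within the scatter. Nothing at hand offers an explanation for this result.

From the compounds shown here alone, all three numbers lie near the top of the scale, so whether this position can affect the read-out at all remains open. A carboxylic acid or a morpholine ring on the same carbonyl carbon could help to settle that.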